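Methoxy for fluoro on the amide-bearing ring

The source may report more compounds than this note shows. Statements on the series, on what has been measured and on what is new or still open speak of the compounds shown alone.

Measured compounds:
compound 1, `COc1ccc(-c2cc(C(=O)Nc3nc4ccc(F)cc4s3)nc3cc(-c4ccccc4)nn23)cc1`, 35500 nM
compound 2, `COc1ccc2nc(NC(=O)c3cc(-c4ccc(F)cc4)n4nc(-c5ccccc5)cc4n3)sc2c1`, 24500 nM

In a functional assay on MCF7 cells (Homo sapiens) for cytotoxicity, read by MTT assay, with a stated time of 48 h (on this read-out lower numbers stand for stronger inhibition and higher numbers for weaker inhibition), compound 2 gives the lowest of the two numbers; its nearest neighbour is compound 1, whose value lies within the scatter of it, so the two cannot be ordered. Compound 3, `COc1ccc(-c2cc(C(=O)Nc3nc4ccc(OC)cc4s3)nc3cc(-c4ccccc4)nn23)cc1`, differs from compound 2 by methoxy in place of fluoro on an aromatic carbon. No measured step of this kind exists among these compounds. Starting from compound 2, the step to compound 3 in this assay is expected to be small, a 1.0-fold higher number from compound 2 to compound 3 (0.01 log units; within the scatter), with no direction beyond the scatter. Compound 3 is therefore estimated at 25000 nM, within 8000 nM to 80000 nM.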

Compound 3, half-maximal inhibitory concentration: 19100 nM
Compound 3: the middle estimate sits 1.3-fold (0.12 log units) above what was measured, and the stated range covers the measured number.
By their numbers in this assay, from the lowest: compounds 3, 2 and 1 (each within the scatter of the next).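

In this assay, the exchange of 4-fluorophenyl for 4-methoxyphenyl now has a measured size (a 1.3-fold lower number from compound 2 to compound 3 (0.11 log units; within the scatter)), and the same exchange of fluoro for methoxy on the amide-bearing ring can also be read (a 1.9-fold lower number from compound 1 to compound 3 (0.27 log units; within the scatter)). Neither site therefore separates methoxy from fluoro on this read-out. Nothing available bears on why these two groups read alike at either site. Still open, going by these compounds, is whether an amine or a carboxylic acid at either site would move the number beyond the scatter.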